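A few compounds are considered here, and "the series" means these few. Any claim that something is new, unique, unknown or untested is made for them only; others in the source may bear on it.

Of the compounds shown here, three have been measured in a physicochemical assay for lipophilicity, at pH 7.4; on this read-out higher numbers stand for higher lipophilicity and lower numbers for lower lipophilicity. Compound 2 `C[C@@H]1CN(c2sc(C(F)(F)F)nc2-c2nc3ccccc3[nH]2)CCN1C(=O)Cn1cccn1` gives 3.4, level at the digits shown with compound 3 `Cc1nc(C)n(CC(=O)N2CCN(c3sc(C(F)(F)F)nc3-c3nc4ccc(C5CCN(C)CC5)cc4[nH]3)C[C@H]2C)n1`, which gives 3.4; together they give the highest numbers of the three. Compound 1 `C[C@@H]1CN(c2sc(C(F)(F)F)nc2-c2nc3cc(OCCO)ccc3[nH]2)CCN1C(=O)Cn1cnc2cccnc21` gives 2.4, a lower number that lies beyond the scatter. Compound 4 `C[C@@H]1CN(c2sc(C(F)(F)F)nc2-c2nc3ccccc3[nH]2)CCN1C(=O)Cn1cnc2c1CCN(C)C2` has not yet been measured in this assay. It differs from compound 2 by a group of 10 heavy atoms (7 carbon, 3 nitrogen; one five-membered aromatic ring with 2 hetero atoms, one six-membered non-aromatic ring with 1 hetero atom) in place of a group of 5 heavy atoms (3 carbon, 2 nitrogen; one five-membered aromatic ring with 2 hetero atoms), on a saturated chain carbon bound to a carbonyl carbon. Among the compounds with values here, no step between measured compounds isolates such a change, so the expectation rests on compound 1, compound 2 and compound 3 alone. The step expected in this assay is a number 0.90 log units lower from compound 2 to compound 4 (beyond the scatter), a fall beyond the scatter. Compound 4 is estimated at 2.5, within a range from 1.8 to 3.2.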

Compound 4, distribution coefficient: 3
Compound 4: the middle estimate sits 0.50 log units below what was measured; low and high end bracket the measured number.
By their numbers in this assay, from the lowest: compound 1; then compound 4; then compounds 2 and 3 (each within the scatter of the next).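

Within the data shown here, putting the group of 10 heavy atoms in place of 1H-pyrazol-1-yl, on a saturated chain carbon bound to a carbonyl carbon, gives in this assay a number 0.40 log units lower from compound 2 to compound 4 (beyond the scatter), the first reading of a single change at this place. The earlier compounds shown here differ from one another in more than one place, so they could not show this step. Nothing available accounts for its size.

Going by these compounds, it remains open how a carboxylic acid or a primary amine in this place would read. Also open, on these data alone, is whether the same exchange gives a similar step on a core carrying a further group, such as the piperidine of compound 3.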